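The compounds below may be only part of what the source reports. "The series", "measured", "known", "first", "only" and "open" are said of these compounds alone.

Working notes on the series. In a functional assay (aorta) with Oryctolagus cuniculus as the target (on this read-out lower numbers stand for tighter binding and higher numbers for weaker binding), compound 1 `CCc1ccc(OCCCN2CCC(C(c3ccc(F)cc3)c3ccc(F)cc3)CC2)c(OC)c1` gives 2.51 nM and compound 2 `COc1cc(C#N)ccc1OCCCN1CCC(C(c2ccc(F)cc2)c2ccc(F)cc2)CC1` gives 2 nM. These two do not separate, with a 1.3-fold lower number from compound 1 to compound 2 (0.10 log units; within the scatter). Compound 3 `Fc1ccc(C(c2ccc(F)cc2)C2CCN(CCCOc3ccc4ccccc4c3)CC2)cc1` gives 7.94 nM, the highest number of the three.

Next is compound 4 `Fc1ccc(C(c2ccc(F)cc2)C2CCN(CCCSc3ccccc3)CC2)cc1`, with phenylsulfanyl in place of (naphthalen-2-yl)oxy on a saturated chain carbon, three bonds along the chain from an amine nitrogen in a ring.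

Two measured steps change the aromatic group on the oxygen: a 3.2-fold higher number from compound 1 to compound 3 (0.50 log units; beyond the scatter) and a 4.0-fold higher number from compound 2 to compound 3 (0.60 log units; beyond the scatter). Both are modest, and both end at the highest number. Going by the values given here, no measured step replaces the oxygen with sulfur, and none has an unsubstituted phenyl, so these steps are only a rough guide to size. In this assay a small shift towards a lower number is expected, probably not beyond the scatter. The estimated step is a 1.3-fold lower number from compound 3 to compound 4 (0.12 log units; within the scatter). For compound 4 the expected value is 6 nM, with an estimated range of 1.6 nM to 22 nM.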

Compound 4, dissociation constant: 3.16 nM
For compound 4 the middle estimate is 1.9-fold (0.28 log units) above the measured one; the range from low to high includes it.
By their numbers in this assay, from the lowest: compounds 2, 1 and 4 (each within the scatter of the next); then compound 3.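

In this assay, going by these compounds alone, the shift seen on leaving the (naphthalen-2-yl)oxy group is a 2.5-fold lower number from compound 3 to compound 4 (0.40 log units; beyond the scatter) and it is the first step here that changes the atom on the chain carbon as well as the aromatic group. Compound 4 does not separate from the two substituted phenoxy compounds, with a 1.6-fold higher number from compound 2 to compound 4 (0.20 log units; within the scatter) and a 1.3-fold higher number from compound 1 to compound 4 (0.10 log units; within the scatter) so phenylsulfanyl at this chain carbon reads the same as 4-cyano-2-methoxyphenoxy and 4-ethyl-2-methoxyphenoxy within the scatter. No available measurement bears on why the number shifts.

The step exchanges both the oxygen for sulfur and two aromatic rings for one, so its size cannot be divided between those changes, and a plain phenoxy group on the same chain carbon would separate them. Also open, on these data alone, is how a longer chain between the sulfur and the ring nitrogen, or an amide in place of the sulfur link, would read.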